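This account rests on a few compounds, and the source may have more. Where it says the series, first, only, none or still open, it means among the compounds named here.

For the measured compounds named here, compound 1 `Clc1ccc(N2CC[C@H]3CN[C@H]3C2)cn1` was tested in a functional assay on HEK293 cells for agonist activity at Neuronal acetylcholine receptor; alpha3/beta4 (Homo sapiens), read by FLIPR (a lower number here means that less compound is needed, a higher number that more compound is needed for the effect), and gives 29 nM, the higher of the two numbers known here. Compound 2 `Cc1cc(N2CC[C@H]3CN[C@H]3C2)cnc1Cl` gives 7.2 nM in this assay, and the change a 4.0-fold lower number from compound 1 to compound 2 (0.61 log units; beyond the scatter) came from a methyl in place of hydrogen on an aromatic carbon. Compound 3 `O=[N+]([O-])c1ccc(N2CC[C@H]3CN[C@H]3C2)cn1` differs from compound 1 by nitro in place of chloro on an aromatic carbon. Going by the values given here, no measured step touches this kind of change, so the only step known says nothing about its direction. For compound 3 the expected result in this assay is 35 nM, within 8 nM to 150 nM, meaning an estimated step of a 1.2-fold higher number from compound 1 to compound 3 (0.08 log units; within the scatter).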

Compound 3, half-maximal effective concentration: 390 nM
Compound 3: the middle estimate sits 11-fold (1.05 log units) below what was measured, outside the stated range (above it).
By their numbers in this assay, from the lowest: compound 2; then compound 1; then compound 3.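

In this assay, for the compounds shown here, this is the first measured change at the position next to the ring nitrogen, and it is not a neutral swap: nitro in place of chloro gives a 13-fold higher number from compound 1 to compound 3 (1.13 log units; beyond the scatter). More compound is therefore needed for the effect once chloro is gone. No measurement available here explains the size of this step. On these data alone, whether any replacement of chloro at this position raises the number, or nitro in particular, stays open. A fluoro, a nitrile or an amine in the same place would help separate these two readings.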